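A few compounds are considered here, and "the series" means these few. Any claim that something is new, unique, unknown or untested is made for them only; others in the source may bear on it.

Of the compounds shown here, two have so far been tested in an ADME assay on CHO-K1 cells (Cricetulus griseus) for activation, read by fluorescence, tested at 10 uM; on this read-out higher numbers stand for a weaker effect at the one concentration tested and lower numbers for a stronger effect. Compound 1 `COc1cc(/C=C/C(=O)/C=C(/C=C/c2ccc(O)c(OC)c2)NCCO)ccc1O` gives 90.9% in this assay, a weak effect at the single concentration tested. Compound 2 `COCCCN1C(/C=C/c2ccc(O)cc2)=CC(=O)CC1c1ccc(O)cc1` gives 91.7% in this assay. Of the two numbers, compound 1 holds the marginally lower one, but the gap between them lies within the scatter of repeated measurements, so the two compounds read alike and neither can be set apart from the other.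

Among the compounds with values here, no step between measured compounds differing in a single place is available, so the next step rests on the structures alone. Compound 3 `COCCNC(=C\C(=O)/C=C/c1ccc(O)c(OC)c1)/C=C/c1ccc(O)c(OC)c1` is built from compound 1 by a small change: methyl in place of hydrogen on an oxygen on a saturated carbon. Both measured compounds sit near the weak end of the read-out, and a change of this size is expected to leave that picture untouched; the step from compound 1 to compound 3 is estimated at a number 0.1 percentage points higher from compound 1 to compound 3 (within the scatter), which is no step beyond the scatter. Compound 3 is therefore expected to give 91% in this assay, with a likely range of 80% to 100%.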

Compound 3, a percentage reported as activity, at one concentration (the size of the read-out at that concentration, not a potency): 84.4%
Estimate against measurement, compound 3: 6.6 percentage points above, within the range that was stated.
By their numbers in this assay, from the lowest: compounds 3, 1 and 2 (each within the scatter of the next).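

Replacing the hydrogen with methyl on this oxygen, which turns the 2-hydroxyethyl chain into a 2-methoxyethyl chain, gives in this assay a number 6.5 percentage points lower from compound 1 to compound 3 (within the scatter). Within the data shown here, this pair offers the first reading of a change in one place, and it shows that the read-out at this position does not separate the hydroxy end from the methoxy end of the chain: compound 1 and compound 3 read alike, and the free hydroxy hydrogen makes no difference that can be told from the scatter. No measured evidence bears on this result, so nothing can be said about what lies behind it.

From the compounds shown here alone, what remains open is whether this position stays as insensitive when the chain carries a different kind of end group, such as an amine or a carboxylic acid, or when a longer chain such as 3-methoxypropyl stands in place of the 2-methoxyethyl chain. Going by these compounds, it is also open whether a change elsewhere on the core of compound 1, for example at its phenolic hydroxy groups, would produce a step beyond the scatter in this assay.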